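The compounds below may be only part of what the source reports. "The series", "measured", "known", "first", "only" and "open" are said of these compounds alone.

Series built on the shared core of compound 1 `COc1cc2c(cc1OC)C(CC(N)=O)CC2`, with the amide end varied. In a functional assay on the whole organism (strain Wistar) for inhibition, with Rattus norvegicus as the target, read by paw edema, with stated times of 60 min and 4 h, at a dose of 100 mg/kg by the oral route (a higher number here means more inhibition at the dose given (going by the name of the read-out), a lower number less inhibition), compound 1 gives 31.3%. Compound 2 `CCN(CC)C(=O)CC1CCc2cc(OC)c(OC)cc21`, with diethylamino in place of amino on the carbonyl carbon, gives 37.5%, a change of a number 6.2 percentage points higher from compound 1 to compound 2 (within the scatter). Compound 3 `COc1cc2c(cc1OC)C(CC(=O)NC1CCCC1)CC2`, with cyclopentyl in place of hydrogen on the amide-type nitrogen, gives 45.3%, a change of a number 14 percentage points higher from compound 1 to compound 3 (beyond the scatter). Between the two substituted amides the step is a number 7.8 percentage points higher from compound 2 to compound 3 (within the scatter).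

Compound 3 thus holds the highest of the three numbers, separated from compound 1 by a gap beyond the scatter but from compound 2 only by a gap within it, so no order between compound 3 and compound 2 can be claimed.

Compound 4 `COc1cc2c(cc1OC)C(CC(=O)NCc1ccccc1)CC2` differs from compound 3 by benzyl in place of cyclopentyl on an amide-type nitrogen. Going by the values given here, the steps that bear on this are the two that change the group on the amide-type nitrogen: cyclopentyl for hydrogen, beyond the scatter but modest, and cyclopentylamino for diethylamino, within the scatter. Exchanging one hydrocarbon group for another on the same nitrogen is therefore expected to give a step of a number 0.3 percentage points lower from compound 3 to compound 4 (within the scatter), that is none beyond the scatter. Compound 4 is expected to give 45%, between 30% and 60%.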

Compound 4, a percentage reported as inhibition, in the whole organism at one dose (the size of the read-out at that dose, not a potency): 18.8%
Compound 4: middle estimate off by 26.2 percentage points, on the high side; the measured number lies below the stated range.
By their numbers in this assay, from the lowest: compound 4; then compounds 1, 2 and 3 (each within the scatter of the next, the first and the last beyond it).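

Working notes on the amide nitrogen: in this assay, hydrocarbon groups at this position are not interchangeable, since benzyl in place of cyclopentyl gives a number 26.5 percentage points lower from compound 3 to compound 4 (beyond the scatter) and the gain seen with cyclopentyl does not extend to benzyl. Benzyl in place of hydrogen gives a number 12.5 percentage points lower from compound 1 to compound 4 (beyond the scatter) and benzylamino in place of diethylamino gives a number 18.7 percentage points lower from compound 2 to compound 4 (beyond the scatter), which makes compound 4 the lowest of the four and shows that, relative to the unsubstituted amide of compound 1, a change at this position can lower the number as well as raise it, with cyclopentyl on the higher side and benzyl on the lower. Nothing available here accounts for the drop with benzyl.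

Still open, on these data alone, is whether the drop follows the aromatic ring or the methylene link of benzyl, which cyclohexylmethyl and phenyl on the same nitrogen would help to separate. Also open, as far as these compounds go, are a longer chain such as phenethyl on this nitrogen and a carboxylic acid in place of the amide at the end of the shared core, and all of these readings rest on a single oral dose.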